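The source may report more compounds than this note shows. Statements on the series, on what has been measured and on what is new or still open speak of the compounds shown alone.

Three compounds share one core and differ only in the group attached to an aromatic nitrogen of a five-membered aromatic ring with two nitrogens. Compound 1 `Cc1c(Nc2nc(N)c3c(C#N)c(N4CCC[C@H]4C)n(C)c3n2)cnn1[C@H]1CCOC1` carries an oxolan-3-yl group there, and in an assay on HEK293 cells for inhibition of Leucine-rich repeat serine/threonine-protein kinase 2 (Homo sapiens), with a stated time of 48 h (on this read-out lower numbers stand for stronger inhibition and higher numbers for weaker inhibition), compound 1 gives 140 nM. Compound 2 `Cc1c(Nc2nc(N)c3c(C#N)c(N4CCC[C@H]4C)n(C)c3n2)cnn1CC1(O)COC1` carries a (3-hydroxyoxetan-3-yl)methyl group, and compound 2 gives 220 nM; the change is a 1.6-fold higher number from compound 1 to compound 2 (0.20 log units; within the scatter). Compound 3 `Cc1c(Nc2nc(N)c3c(C#N)c(N4CCC[C@H]4C)n(C)c3n2)cnn1C1COC1` carries an oxetan-3-yl group, and compound 3 gives 300 nM. Among the three numbers, that of compound 3 is the largest, but only the step of a 2.1-fold higher number from compound 1 to compound 3 (0.33 log units; beyond the scatter) lies beyond the scatter, whereas the step of a 1.4-fold higher number from compound 2 to compound 3 (0.13 log units; within the scatter) does not.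

Among the measured compounds shown here, compound 4 `Cc1c(Nc2nc(N)c3c(C#N)c(N4CCC[C@H]4C)n(C)c3n2)cnn1[C@@H]1CCOC1` is the next compound. oxolan-3-yl in place of oxetan-3-yl on an aromatic nitrogen Compound 4 thus carries the same group as compound 1, but with the opposite arrangement at the single stereocentre of that group. The measured step that bears most directly on this change is the reverse one, a 2.1-fold higher number from compound 1 to compound 3 (0.33 log units; beyond the scatter), which was modest. Returning from the four-membered ring to the five-membered ring is therefore expected to lower the number by a similarly modest amount, although the opposite arrangement at the stereocentre has no measured counterpart and leaves the expectation uncertain. For compound 4 the expected value is 170 nM, within the range 60 nM to 500 nM, which means an expected step of a 1.8-fold lower number from compound 3 to compound 4 (0.25 log units; within the scatter).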

Compound 4, half-maximal inhibitory concentration: 180 nM
Compound 4: middle estimate off by 1.1-fold (0.02 log units), on the low side; low and high end bracket the measured number.
By their numbers in this assay, from the lowest: compounds 1, 4, 2 and 3 (each within the scatter of the next, the first and the last beyond it).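

Swapping the configuration at the single stereocentre of the oxolan-3-yl group gives a 1.3-fold higher number from compound 1 to compound 4 (0.11 log units; within the scatter), so in this assay the two arrangements at this position cannot be told apart. This comparison isolates the stereocentre itself, and nothing else in the molecule can account for the step, which rests on the following: the fact that compounds 1 and 4 differ only in the configuration as drawn. Among the compounds shown here, it also narrows what the earlier compounds suggested about the oxolan-3-yl and oxetan-3-yl groups, since the one step beyond the scatter between them belongs to a single configuration, while the other configuration gives a 1.7-fold lower number from compound 3 to compound 4 (0.22 log units; within the scatter), which lies within it, and the comparison with the (3-hydroxyoxetan-3-yl)methyl group, a 1.2-fold lower number from compound 2 to compound 4 (0.09 log units; within the scatter), lies within it as well.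

The compounds shown leave open whether this position stays as tolerant with a six-membered ring such as oxan-4-yl, a ring carrying an amine such as piperidin-4-yl, or an open chain such as 2-methoxyethyl. They also leave open whether the two configurations of the oxolan-3-yl group would stay this close on a different core.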